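Replacing a basic amine linker with a benzyl amide

The source may hold more compounds than are shown below. What is called first, only, known or untested is meant among the compounds shown, and "the series" means these compounds.

Of the compounds shown here, three sharing one core have been tested in a functional assay on BMMC cells (Mus musculus, strain C57BL/6) for inhibition, with stated times of 5 days and 48 h; a lower number here means a stronger inhibitor, a higher number a weaker inhibitor. Compound 1 `C=C1CC[C@@H]2[C@](C)(CNCc3cccc(OC)c3)[C@H](O)CC[C@@]2(C)[C@@H]1/C=C/C1=CCOC1=O` gives 780 nM; compound 2 `C=C1CC[C@@H]2[C@](C)(CNCc3ccc(F)cc3)[C@H](O)CC[C@@]2(C)[C@@H]1/C=C/C1=CCOC1=O` gives 350 nM; compound 3 `C=C1CC[C@@H]2[C@](C)(CNCc3ccncc3)[C@H](O)CC[C@@]2(C)[C@@H]1/C=C/C1=CCOC1=O` gives 2030 nM. Compound 3 therefore stands at the highest number of the three, the weakest inhibitor so far, with compound 1 nearest and compound 2 furthest from it.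

Compound 4 `C=C1CC[C@H]2[C@@](C)(CC[C@@H](O)[C@@]2(C)C(=O)NCc2ccccc2)[C@@H]1/C=C/C1=CCOC1=O` differs from compound 3 as follows: benzylcarbamoyl in place of (((pyridin-4-yl)methyl)amino)methyl on a saturated ring carbon. Two parts of this change can be weighed. The aromatic ring moves from a nitrogen-containing ring to a carbon-only ring, and among the measured compounds that kind of swap always went with lower numbers: a 5.8-fold higher number from compound 2 to compound 3 (0.76 log units; beyond the scatter) and a 2.6-fold higher number from compound 1 to compound 3 (0.42 log units; beyond the scatter) both run uphill toward the pyridine, while a 2.2-fold lower number from compound 1 to compound 2 (0.35 log units; beyond the scatter) shows that two carbon-only rings sit close together. Going by the values given here, the second part, an amide carbonyl in place of the amine, has no measured counterpart here, so its effect is unknown.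

Weighing the ring evidence against the unmeasured amide, a modest improvement is expected for compound 4, a 2.5-fold lower number from compound 3 to compound 4 (0.40 log units; beyond the scatter), giving an estimate of 800 nM with a range from 200 nM to 3200 nM.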

Compound 4, half-maximal inhibitory concentration: 19400 nM
Beside the measured number, compound 4's estimate is 24-fold (1.38 log units) below it; measured number above the stated range.
By their numbers in this assay, from the lowest: compound 2; then compound 1; then compound 3; then compound 4.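

In this assay the move to benzylcarbamoyl on this saturated ring carbon gives the largest steps seen so far: a 9.6-fold higher number from compound 3 to compound 4 (0.98 log units; beyond the scatter) and, larger still, a 25-fold higher number from compound 1 to compound 4 (1.40 log units; beyond the scatter) and a 55-fold higher number from compound 2 to compound 4 (1.74 log units; beyond the scatter). Compound 4 carries a carbon-only aromatic ring, as compound 1 and compound 2 do, yet it is the weakest inhibitor of the four, so the kind of ring, which was all that varied among the earlier compounds, cannot by itself account for this result and the change from the amine chain to the amide comes into focus. No measurement shown here explains why this change weakens inhibition so strongly.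

Every step to compound 4 changes the link and the aromatic ring together, so the share of each remains unsettled. A ((benzyl)amino)methyl group would put the unsubstituted ring of compound 4 on the amine chain, and a longer chain, (benzylcarbamoyl)methyl, would show whether the amide itself or its shorter link to the ring carbon goes with the loss.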